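A few compounds are considered here, and "the series" means these few. Any claim that something is new, unique, unknown or untested is made for them only; others in the source may bear on it.

Measured compounds in an ADME assay on Huh-7 cells (Homo sapiens) for cytotoxicity, read by MTT assay, with a stated time of 72 h; on this read-out higher numbers stand for lower toxicity in this test and lower numbers for higher toxicity in this test:
- compound 1 `COc1ccc(-c2cc(C(F)(F)F)c3c(N)c(C(N)=O)sc3n2)cc1`: 46400 nM
- compound 2 `COc1cccc(-c2cc(C(F)(F)F)c3c(N)c(C(N)=O)sc3n2)c1`: > 20000 nM

Going by the values given here, compound 1 gives 46400 nM in this assay and is the only compound with a number. Compound 2 reaches > 20000 nM, which is a limit of the assay rather than a number. Among the compounds with values here, the one step, a step that the limit leaves unreadable from compound 1 to compound 2, is therefore unreadable; this follows from the limit of > 20000 nM in this assay, at which 1 of the 2 values shown sits.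

Compound 3 `COc1ccc(-c2ccc3c(N)c(C(N)=O)sc3n2)cc1` differs from compound 1 by hydrogen in place of trifluoromethyl on an aromatic carbon. Within the data shown here, no measured step touches this position, so nothing shows a direction. Compound 3 is expected to show a 1.0-fold lower number from compound 1 to compound 3 (0.00 log units; within the scatter), a step within scatter. The estimate for compound 3 is 46000 nM, in the range 15000 nM to 120000 nM.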

Compound 3, half-maximal cytotoxic concentration: < 400 nM
Compound 3: a limit, no number (the forecaster's own chance of this, stated with the estimate: 35%); at least 110-fold (2.06 log units) between middle value and limit.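

In this assay, going by these compounds alone, this position gives the series its only readable step: hydrogen in place of trifluoromethyl on this aromatic carbon gives an at least 110-fold lower number from compound 1 to compound 3 (2.06 log units; beyond the scatter), so toxicity in this test depends strongly on what sits here. For compound 3, < 400 nM is a limit and not a number. The size of the step is known only as a bound: the limit of < 400 nM in this assay, at which 1 of the 3 values shown sits.

Still open, on these data alone, is whether a methyl group, a chlorine atom or an amine on this carbon would stay close to compound 1 or fall towards compound 3. As far as these compounds go, the same change with the 3-methoxyphenyl group of compound 2 also remains open.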